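The source may hold more compounds than are shown below. What is called first, only, known or untested is meant among the compounds shown, and "the series" means these compounds.

Compound 1, whose structure is `COc1ccc(Oc2cccc(CN3CCC(n4cc(C)c(=O)[nH]c4=O)CC3)c2)cc1`, was tested in an ADME assay on MRC5 cells (Homo sapiens) for cytotoxicity, read by fluorescence and resazurin assay, with a stated time of 3 days (on this read-out higher numbers stand for weaker inhibition and lower numbers for stronger inhibition), where compound 1 gives 28000 nM. For the measured compounds named here, this is the only number that the set shows; the remaining result is a limit rather than a number. Compound 2, with structure `Cc1cn(C2CCN(Cc3ccnc(Oc4ccccc4)c3)CC2)c(=O)[nH]c1=O`, reaches only the limit of this assay, and in this assay compound 2 gives > 64000 nM. That limit is described by the limit of > 64000 nM in this assay, at which 1 of the 2 values shown sits. Compound 2 stops at a limit. Going by the values given here, no measured step between two numbers exists, so compound 1 stands alone as a measured point.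

Compound 3, with structure `Cc1cn(C2CCN(Cc3cccc(Oc4cccc(C(F)(F)F)c4)c3)CC2)c(=O)[nH]c1=O`, has not been measured in this assay. It differs from compound 1 in one place: 3-(trifluoromethyl)phenyl in place of 4-methoxyphenyl on an oxygen on an aromatic ring.

Among the compounds with values here, with no measured step to lean on, the expectation for this change is a small move, which in this assay is estimated as a step of a 1.4-fold lower number from compound 1 to compound 3 (0.15 log units; within the scatter), if any change beyond the usual scatter appears at all. Compound 3 is therefore estimated at 20000 nM in this assay, with a range from 7000 nM to 64000 nM.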

Compound 3, half-maximal inhibitory concentration: 12400 nM
Compound 3: the middle estimate sits 1.6-fold (0.21 log units) above what was measured; the measured number falls inside the stated range.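

Placing 3-(trifluoromethyl)phenyl instead of 4-methoxyphenyl on the oxygen gives the first step between two measured numbers in this assay (a 2.3-fold lower number from compound 1 to compound 3 (0.35 log units; beyond the scatter)), so the group at this place can move the read-out beyond the usual scatter, here towards stronger inhibition of the cells. The step is modest, and the change replaces the methoxy group with a trifluoromethyl group while also moving from a 4-substituted to a 3-substituted ring, so this one step cannot show which of these differences matters. The results shown here offer no measurement that bears on why the number moved.

Going by these compounds, it remains open whether the same trifluoromethyl group would give the same number if it sat where the methoxy group sits in compound 1, and whether the methoxy group would behave differently in the place it occupies in compound 3. On these data alone, it is also open how the read-out would respond to a quite different group on this ring, such as an amine or a carboxylic acid, and whether the direction of this single step would hold.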